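A few compounds are considered here, and "the series" means these few. Any claim that something is new, unique, unknown or untested is made for them only; others in the source may bear on it.

compound 1 `Nc1nc(N)nc(N/N=C/c2cccs2)n1`: 78200 nM
compound 2 `Nc1nc(N)nc(N/N=C/c2ccc([N+](=O)[O-])o2)n1`: 183000 nM
compound 3 `CN(C)c1nc(N)nc(N/N=C/c2ccc([N+](=O)[O-])o2)n1`: 110000 nM

All three values come from a functional assay on L6 cells (Rattus norvegicus) for cytotoxicity; on this read-out higher numbers stand for weaker inhibition and lower numbers for stronger inhibition. Compound 2 sits at the top end of these numbers, within the scatter of compound 3 and beyond the scatter from compound 1.

The next step leads to compound 4 `Nc1nc(N)nc(N/N=C/c2ccco2)n1`, with hydrogen in place of nitro on an aromatic carbon. Among the compounds with values here, no measured step covers this change directly. The only one, a 1.7-fold lower number from compound 2 to compound 3 (0.22 log units; within the scatter), is a dimethylamino for amino exchange elsewhere on the molecule, so it gives only a sense of how little the numbers have moved so far. Compound 1 also has no nitro, and its 78200 nM points to a modestly lower number, although its ring differs from that of compound 2.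

The expected change is small and in the lower direction, within the scatter: a 1.5-fold lower number from compound 2 to compound 4 (0.18 log units; within the scatter). For compound 4 the estimated value is 120000 nM, with an expected range of 55000 nM to 250000 nM.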

Compound 4, half-maximal inhibitory concentration: > 400000 nM
Compound 4 ended at the assay's limit; the forecaster's own chance of this, stated with the estimate: 15%; middle value at least 3.3-fold (0.52 log units) from the limit.
By their numbers in this assay, from the lowest: compounds 1, 3 and 2 (each within the scatter of the next, the first and the last beyond it). At a limit, above all of these: compound 4.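

Compound 4 stands at a limit of this assay, not at a number: the limit of > 400000 nM in this assay, at which 1 of the 4 values shown sits.
On the aromatic carbon next to the ring oxygen, hydrogen in place of nitro gives an at least 2.1-fold higher number from compound 2 to compound 4 (0.33 log units; beyond the scatter), so this change registers beyond the scatter, unlike the dimethylamino for amino exchange, which gives a 1.7-fold lower number from compound 2 to compound 3 (0.22 log units; within the scatter).
Furan-2-yl in place of thiophen-2-yl gives an at least 5.1-fold higher number from compound 1 to compound 4 (0.70 log units; beyond the scatter), which shows that the lack of nitro does not alone set the number, since the thiophen-2-yl compound also lacks nitro and still gives a measurable value.

As far as these compounds go, how far both steps extend past the limit stays open. Also open, from the compounds shown here alone, is whether chlorine or methyl on the same ring carbon would read closer to nitro or to hydrogen.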